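The source may hold more compounds than are shown below. What is called first, only, known or untested is meant among the compounds shown, and "the series" means these compounds.

Compound 1 `C=C1C(=O)O[C@H]2CC3=C[C@H](C/C(C)=C/[C@@H](OC(=O)CCCCBr)[C@H]12)OC3=O` and compound 2 `C=C1C(=O)O[C@H]2CC3=C[C@H](C/C(C)=C/[C@@H](OC(=O)C4(NC(=O)OCc5ccccc5)CC4)[C@H]12)OC3=O` share one core and differ only in the ester group hanging from it. In a functional assay on A549 cells (Homo sapiens) for cytotoxicity, read by MTT assay, with a stated time of 48 h (on this read-out higher numbers stand for weaker inhibition and lower numbers for stronger inhibition), compound 1 gives only a limit, > 10000 nM, not a measured number. In this assay compound 2 gives 5800 nM. Compound 3 `C=C1C(=O)O[C@H]2CC3=C[C@H](C/C(C)=C/[C@@H](OC(=O)/C=C/c4cccs4)[C@H]12)OC3=O` has not yet been measured; it carries 2-(thiophen-2-yl)ethenyl in place of 4-bromobutyl on a carbonyl carbon. Among the compounds with values here, no measured pair covers this change, so the direction is open; a small to moderate gain toward stronger inhibition, perhaps beyond the scatter, is plausible but not assured. Compound 3 is expected near 6000 nM, between 2000 nM and 20000 nM. The step this estimate implies is an at least 1.6-fold lower number from compound 1 to compound 3 (0.22 log units; that floor lies within the scatter), an expectation only.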

Compound 3, half-maximal inhibitory concentration: 4300 nM
Beside the measured number, compound 3's estimate is 1.4-fold (0.14 log units) above it, within the range that was stated.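

In this assay, the group on this carbonyl carbon can move the read-out: 2-(thiophen-2-yl)ethenyl in place of 4-bromobutyl gives an at least 2.3-fold lower number from compound 1 to compound 3 (0.36 log units; beyond the scatter). This is the only readable step at this place, and it marks a floor rather than the full size of the change, because compound 1 stands at a limit: the limit of > 10000 nM in this assay, at which 1 of the 3 values shown sits.

The compounds shown leave open whether the thiophene ring, the double bond or both matter. A furan ring in place of the thiophene, or a 2-(thiophen-2-yl)ethyl group without the double bond, would help to separate these parts.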